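The source may report more compounds than this note shows. Statements on the series, on what has been measured and on what is new or still open speak of the compounds shown alone.

Compound 1 `ClCc1ccc(Cn2cnc3c(Cl)ncnc32)cc1`: 9330 nM
Compound 2 `Nc1nc(Cl)c2ncn(Cc3ccccc3CCl)c2n1`: 69200 nM
Compound 3 `ClCc1ccc(Cn2cnc3c(Cl)nc(Cl)nc32)cc1`: 50100 nM

In a functional assay on NCI-H322M cells (Homo sapiens) for cytotoxicity, read by sulforhodamine B assay, with a stated time of 48 h (a higher number here means that more compound is tolerated, a lower number that less compound is tolerated), compound 2 gives the highest of the three numbers. Compound 3 lies close to it, with a gap that is within the usual scatter, whereas compound 1 gives a clearly lower number, a gap beyond the scatter. Compound 4 `ClCc1ccccc1Cn1cnc2c(Cl)nc(Cl)nc21` has not yet been measured. It differs from compound 2 in one place: chloro in place of amino on an aromatic carbon.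

Going by the values given here, only one measured step concerns a change on an aromatic carbon of the shared core: a 5.4-fold higher number from compound 1 to compound 3 (0.73 log units; beyond the scatter). That step set a chloro group where hydrogen had been. Among the compounds with values here, the step toward compound 4 also brings in a chloro group, but at the same time an amino group is lost, and no measured pair shows amino giving way to chloro, so the measured step bears on it only loosely. The entering chloro resembles what raised the number from compound 1 to compound 3, while the loss of the amino group has no guide in the data. A small step is therefore expected, most likely none beyond the scatter, with the number for compound 4 expected close to that of compound 2: a 1.3-fold lower number from compound 2 to compound 4 (0.10 log units; within the scatter). Compound 4 is estimated at 55000 nM, with a likely range from 20000 nM to 150000 nM.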

Compound 4, concentration lethal to 50% of the cells: 5880 nM
Compound 4: the middle estimate sits 9.4-fold (0.97 log units) above what was measured; the measured number lies below the stated range.
By their numbers in this assay, from the lowest: compounds 4 and 1 (each within the scatter of the next); then compounds 3 and 2 (each within the scatter of the next).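

In this assay, setting chloro in place of amino on this aromatic carbon, between two ring nitrogen atoms, gives a 12-fold lower number from compound 2 to compound 4 (1.07 log units; beyond the scatter), so this carbon of the shared core is sensitive to which group it carries. Going by these compounds alone, the only earlier change here, a 5.4-fold higher number from compound 1 to compound 3 (0.73 log units; beyond the scatter), also brought in chloro, yet there the number rose when chloro replaced hydrogen, whereas here it falls when chloro replaces amino; chloro entering therefore has no fixed direction of its own, and the result depends on what it replaces, although the two pairs also differ in where the chloromethyl group sits on the benzene ring. No measurement on hand explains why the amino compound tolerates so much more than its chloro partner.

The compounds shown leave open how much of this step comes from the amino group leaving and how much from chloro entering, which a partner of compound 4 with hydrogen on this carbon would help to separate. Also open, going by these compounds, is where other groups on this carbon, such as methoxy or a methylamino group, would fall relative to amino and chloro.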